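Lengthening a Carbamate Chain Across Two Charged Cores

A few compounds are considered here, and "the series" means these few. Any claim that something is new, unique, unknown or untested is made for them only; others in the source may bear on it.

Compound 1, `C(CN1CC[N+]2(CCCC2)CC1)CN1CC[N+]2(CCCC2)CC1`: in a functional assay on the whole organism with Mus musculus as the target, in the writhing test, at a dose of 0.04 mmol/kg by the subcutaneous route (a higher number here means more inhibition at the dose given (going by the name of the read-out), a lower number less inhibition), compound 1 gives 81%.
Compound 2, `CCCNC(=O)OC(CC1CC[N+]2(CCCC2)CC1)CC1CC[N+]2(CCCC2)CC1`: in this assay compound 2 gives 70.9%.

Among the compounds with values here, compound 2 stands lowest of the two numbers measured so far. Its nearest neighbour is compound 1, whose value lies higher by a gap that is beyond the usual scatter of this measurement. The two compounds are not joined by a single-point step, so only their two values can be set side by side; no cause for the gap can be read from them.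

Compound 3, `CCCCCNC(=O)OC(CC1CC[N+]2(CCCC2)CC1)CC1CC[N+]2(CCCC2)CC1`, has not yet been measured. It differs from compound 2 in one place: ethyl in place of hydrogen on a saturated chain carbon, three bonds along the chain from an amide-type nitrogen. Within the data shown here, no measured step of this kind exists among the compounds above, so the size of the change in this assay cannot be anchored to a precedent. The expectation is a small step, within or only slightly beyond the scatter, with no clear direction favoured. Compound 3 is therefore expected to give 68%, in a range from 50% to 85%. The estimated step is a number 2.9 percentage points lower from compound 2 to compound 3 (within the scatter).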

Compound 3, a percentage reported as inhibition, in the whole organism at one dose (the size of the read-out at that dose, not a potency): 75.2%
For compound 3 the middle estimate is 7.2 percentage points below the measured one; low and high end bracket the measured number.
By their numbers in this assay, from the lowest: compounds 2, 3 and 1 (each within the scatter of the next, the first and the last beyond it).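

Within the data shown here, this is the first measured step at this position: in this assay, ethyl in place of hydrogen on a saturated chain carbon, three bonds along the chain from an amide-type nitrogen, gives a number 4.3 percentage points higher from compound 2 to compound 3 (within the scatter). Read as propyl to pentyl, the change adds two carbons to the chain, yet at this single dose the read-out does not separate the two compounds, so this pair shows that the position accepts the longer chain without a difference that can be told from ordinary scatter. Nothing measured here offers an explanation for this result.

One step within the scatter cannot establish a trend along the chain, and a butyl chain, a chain longer than pentyl, or an amine or a carboxylic acid at the chain end could each give a different picture. Steps from compound 1 to the other two cannot be read because it differs from them in more than one place, and a single-dose read-out gives no potency for any of the three.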